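Replacing 3,4-dichlorophenyl on the amine side chain

This account rests on a few compounds, and the source may have more. Where it says the series, first, only, none or still open, it means among the compounds named here.

Compound 1 `COc1ccc2nccc(CC[C@H]3CC[C@H](NCc4ccc(Cl)c(Cl)c4)CC3)c2c1` is the starting point of this step, but it offers no number to start from. In an ADME assay on K562 cells (Homo sapiens) for antiproliferative activity (a higher number here means a weaker inhibitor, a lower number a stronger inhibitor), compound 1 is recorded as "not determined" (no result reported) and so gives no reference value. Among the measured compounds shown here, the only measured neighbour is compound 2 `COc1ccc2nccc(CC[C@H]3OC[C@H](NCc4cc5c(cn4)OCCC5)CO3)c2c1` which has a different core, and compound 2 reads 32000 nM in this assay as the single number so far.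

Compound 3 `COc1ccc2nccc(CC[C@H]3CC[C@H](NCc4ccc5c(n4)NC(=O)CO5)CC3)c2c1` keeps the core of compound 1. For the measured compounds named here, the one change is a group of 11 heavy atoms (7 carbon, 2 nitrogen, 2 oxygen; one six-membered non-aromatic ring with 2 hetero atoms, one six-membered aromatic ring with 1 hetero atom) in place of a group of 8 heavy atoms (6 carbon, 2 chlorine; one six-membered aromatic ring of carbon only), on a saturated chain carbon bound to an amine nitrogen and the incoming group, unlike the 3,4-dichlorophenyl it replaces, contains hetero atoms.

The size of the step from compound 1 cannot be read from the data, since that compound has no value. Going by the values given here, the only anchor is compound 2 at 32000 nM and compound 3 is expected to sit in the same weak region, with no shift beyond the scatter in either direction. A report of only a limit is also possible.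

Compound 3 is estimated at 30000 nM with an expected range from 8000 nM to 100000 nM in this read-out.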

Compound 3, half-maximal inhibitory concentration: 12000 nM
For compound 3 the middle estimate is 2.5-fold (0.40 log units) above the measured one, and the stated range covers the measured number.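

In this assay no step can be read from compound 1 to compound 3: compound 1 has no number, and compound 2 differs from compound 3 in more than one place. As far as these compounds go, whether replacing 3,4-dichlorophenyl on the shared core changes the read-out, and in which direction, stays open. Nothing available bears on the result for compound 3.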